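Shortening the sulfur-linked chain in a diphosphate series

A few compounds are considered here, and "the series" means these few. Any claim that something is new, unique, unknown or untested is made for them only; others in the source may bear on it.

Two compounds of this series have numbers in an in vitro functional assay on 1321-N1 cells for agonist activity at P2Y purinoceptor 6 (Homo sapiens); a higher number here means that more compound is needed for the effect, a lower number that less compound is needed. Compound 1 `CCCCCCSc1ccn([C@@H]2O[C@H](COP(=O)(O)OP(=O)(O)O)[C@@H](O)[C@H]2O)c(=O)n1` gives 4900 nM and has the higher of the two numbers, but compound 2 `N[C@@H]1[C@H](O)[C@@H](COP(=O)(O)OP(=O)(O)O)O[C@H]1n1ccc(=O)[nH]c1=O` with 3900 nM sits within the scatter of it, so no order between the two is claimed. Compound 3 `C=CCSc1ccn([C@@H]2O[C@H](COP(=O)(O)OP(=O)(O)O)[C@@H](O)[C@H]2O)c(=O)n1` differs from compound 1 by vinyl in place of pentyl on a saturated chain carbon bound to a sulfur. Going by the values given here, no measured step tells what such a change does; the expectation for compound 3 is therefore a step of a 1.4-fold lower number from compound 1 to compound 3 (0.15 log units; within the scatter) that stays at or near the scatter, direction uncertain. Compound 3 is estimated at 3500 nM, with a range from 900 nM to 14000 nM.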

Compound 3, half-maximal effective concentration: 560 nM
For compound 3 the middle estimate is 6.3-fold (0.80 log units) above the measured one, outside the stated range (below it).
By their numbers in this assay, from the lowest: compound 3; then compounds 2 and 1 (each within the scatter of the next).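

The sulfur-linked chain on the core of compound 1 is not a silent site: hexylsulfanyl to allylsulfanyl gives an 8.8-fold lower number from compound 1 to compound 3 (0.94 log units; beyond the scatter) in this assay. This single step changes chain length and introduces a double bond together, so it does not assign the shift to either change. Nothing available accounts for the size of the shift.

On these data alone, whether a saturated propyl chain on the sulfur would give a similar number remains open. So does the result of replacing the allyl with a benzyl group.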